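Adding a chloro group to compound 3

The source may report more compounds than this note shows. Statements on the series, on what has been measured and on what is new or still open speak of the compounds shown alone.

In a functional assay on UACC-257 cells (Homo sapiens) for inhibition, with a stated time of 48 h (a higher number here means a weaker inhibitor of growth, a lower number a stronger inhibitor of growth), compound 3 (`C=CCc1c(O)c(C(=O)/C=C/c2ccccc2)c(OC)c2ccoc12`) gives 2560 nM as its number. Compound 2 (`COc1c(C(=O)/C=C/c2ccc(Cl)cc2)c(O)c(Br)c2occc12`) gives 4980 nM in this assay and so lies within the usual scatter of compound 3. For compound 1 (`COc1ccccc1/C=C/C(=O)c1c(O)cc2occc2c1OC`) the result is a limit and not a number (> 100000 nM).

Compound 4 (`C=CCc1c(O)c(C(=O)/C=C/c2ccc(Cl)cc2)c(OC)c2ccoc12`) is compound 3 with chloro in place of hydrogen on an aromatic carbon, para to a large group (chloro in place of hydrogen on an aromatic carbon). Its phenyl thus becomes 4-chlorophenyl. Among the measured compounds shown here, no measured pair isolates this change. The closest guide is compound 2, which carries the same 4-chlorophenyl and gives 4980 nM although it differs from compound 4 elsewhere on the core. A step beyond the scatter in this assay is therefore not expected, and the direction remains uncertain. The estimated step is small (a 1.2-fold lower number from compound 3 to compound 4 (0.07 log units; within the scatter)) and stays within the scatter. For compound 4 the expected value is 2200 nM with an estimated range from 800 nM to 6500 nM in the coming measurement.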

Compound 4, concentration for 50% growth inhibition: 2390 nM
Estimate against measurement, compound 4: 1.1-fold (0.04 log units) below; low and high end bracket the measured number.
By their numbers in this assay, from the lowest: compounds 4, 3 and 2 (each within the scatter of the next, the first and the last beyond it). At a limit, above all of these: compound 1.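

In this assay, the pair of compound 3 and compound 4 isolates chloro in place of hydrogen on an aromatic carbon, para to a large group, and gives a 1.1-fold lower number from compound 3 to compound 4 (0.03 log units; within the scatter), so the two compounds cannot be told apart at this position. With the 4-chlorophenyl held fixed, the other pair reads allyl in place of bromo on an aromatic carbon and gives a 2.1-fold lower number from compound 2 to compound 4 (0.32 log units; beyond the scatter), a modest step and the only one here beyond the scatter. Nothing available explains either step.

On these data alone, it remains open whether an amine or a carboxylic acid at the para position of this phenyl would give a step beyond the scatter. As far as these compounds go, it is equally open whether a longer chain in place of allyl would extend the step seen from bromo to allyl.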